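The compounds below may be only part of what the source reports. "The series", "measured", "known", "first", "only" and "open" are said of these compounds alone.

Compound 2 `COc1ncc(-c2cc(OC3CCOC(C)(C)C3)c3ncnc(C)c3c2)cc1NS(=O)(=O)c1ccc(F)cc1F` and compound 1 `COc1ncc(-c2cc(OC3CCCC3)c3ncnc(C)c3c2)cc1NS(=O)(=O)c1ccc(F)cc1F` share one core and differ only in the group on an oxygen on an aromatic ring. In an ADME assay on Caco-2 cells (Homo sapiens) for permeability, read by LC-MS, in the apical to basolateral direction, with a stated time of 90 min (on this read-out higher numbers stand for higher permeability and lower numbers for lower permeability), compound 2 gives 31 10^-6 cm/s, and compound 1 gives 28 10^-6 cm/s; the step of a 1.1-fold higher number from compound 1 to compound 2 (0.04 log units; within the scatter) is within the scatter, so the two numbers cannot be told apart. Compound 3 `COc1ncc(-c2cc(OC3CCN(C)CC3)c3ncnc(C)c3c2)cc1NS(=O)(=O)c1ccc(F)cc1F` takes the next step: 1-methylpiperidin-4-yl in place of 2,2-dimethyloxan-4-yl on an oxygen on an aromatic ring. Going by the values given here, the only measured step, from compound 1 to compound 2, swapped one ring without a nitrogen for another, so no measured step covers the entering group, and the expectation rests on little. Compound 3 is therefore expected to come out somewhat lower in this assay, with a step of a 2.6-fold lower number from compound 2 to compound 3 (0.41 log units; beyond the scatter) from compound 2 to compound 3, though a number within the scatter of compound 2 would not surprise. The estimate for compound 3 is 12 10^-6 cm/s, with a range from 4 10^-6 cm/s to 30 10^-6 cm/s.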

Compound 3, apparent permeability: 4.5 10^-6 cm/s
For compound 3 the middle estimate is 2.7-fold (0.43 log units) above the measured one; the measured number falls inside the stated range.
By their numbers in this assay, from the lowest: compound 3; then compounds 1 and 2 (each within the scatter of the next).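

In this assay, the group on an oxygen on an aromatic ring turns out to matter: 1-methylpiperidin-4-yl brings a 6.9-fold lower number from compound 2 to compound 3 (0.84 log units; beyond the scatter) and also a 6.2-fold lower number from compound 1 to compound 3 (0.79 log units; beyond the scatter) in comparison with the other two groups. Going by these compounds alone, this is the first change at this position that clearly moves the number, since cyclopentyl and 2,2-dimethyloxan-4-yl could not be told apart, so the ring that holds a nitrogen stands alone among the three. Nothing available here explains the drop.

The compounds shown leave open whether the ring nitrogen or the methyl on it goes with the lower number. A 1-acetylpiperidin-4-yl or a plain piperidin-4-yl group at the same place would help separate those two possibilities.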